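Swapping a Benzyl Ring Nitrogen into Compound 1

This account rests on a few compounds, and the source may have more. Where it says the series, first, only, none or still open, it means among the compounds named here.

Measured so far:
compound 1, `Cc1nc2c(OCc3ccccc3)cccn2c1N`: 99%
compound 2, `CC(C)c1nc2c(OCc3ccccc3)cccn2c1N`: 0%
compound 3, `Cc1nc2c(OCc3ccc(F)cc3)cccn2c1N`: 95%

In a functional assay on the whole organism with Rattus norvegicus as the target, at a dose of 40 mg/kg by the intraperitoneal route (a higher number here means more inhibition at the dose given (going by the name of the read-out), a lower number less inhibition), compound 1 gives 99%, the highest of the three numbers. Its nearest neighbour is compound 3, which gives 95%, and the two differ only by a number 4 percentage points lower from compound 1 to compound 3 (within the scatter), a gap that falls inside the ordinary scatter of such readings. Compound 2 sits far away at 0%; the change from compound 1 to compound 2 is a number 99 percentage points lower from compound 1 to compound 2 (beyond the scatter), well beyond the scatter.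

The unmeasured compound 4, `Cc1nc2c(OCc3ccccn3)cccn2c1N`, differs from compound 1 by pyridin-2-yl in place of phenyl on a saturated chain carbon bound to an oxygen on an aromatic ring. Among the compounds with values here, no measured step touches this exact exchange. The closest guide is compound 3, where a small change on the same ring left the number within scatter, whereas the large loss in compound 2 came from a change on the shared core, not on this ring. The step to compound 4 is therefore expected to be small or none beyond the scatter, with some risk of a drop, so the step of a number 14 percentage points lower from compound 1 to compound 4 (beyond the scatter) is what is estimated here. In this assay compound 4 is expected to give about 85%, within a range from 50% to 100%.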

Compound 4, a percentage reported as inhibition, in the whole organism at one dose (the size of the read-out at that dose, not a potency): 16%
The estimate for compound 4 lay 69 percentage points above the measured number, outside the stated range (below it).
By their numbers in this assay, from the lowest: compound 2; then compound 4; then compounds 3 and 1 (each within the scatter of the next).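

The ring on this saturated chain carbon bound to an oxygen on an aromatic ring turns out to be far less forgiving than compound 3 suggested: in this assay, pyridin-2-yl in place of phenyl gives a number 83 percentage points lower from compound 1 to compound 4 (beyond the scatter), a large step beyond the scatter, although the two groups have the same count of heavy atoms and differ by one ring nitrogen and one hydrogen-bond acceptor. Within the data shown here, until now the only change on this ring was fluoro, with a number 4 percentage points lower from compound 1 to compound 3 (within the scatter), and the only large loss came from the shared core, with a number 99 percentage points lower from compound 1 to compound 2 (beyond the scatter), so this result shows that a change on the ring itself can also remove nearly all of the inhibition. Nothing available here bears on why the number falls so far.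

The compounds shown leave open whether pyridin-3-yl or pyridin-4-yl would lose as much as pyridin-2-yl, and so whether the loss follows any ring nitrogen or only this one arrangement. They also leave open whether a methoxy group or a chlorine on the phenyl ring would stay as close to compound 1 as the fluoro of compound 3 does.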